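Chloro for Methoxy in a Nitrophenylhydrazone Series

A few compounds are considered here, and "the series" means these few. Any claim that something is new, unique, unknown or untested is made for them only; others in the source may bear on it.

Compound 2 `COc1ccc(C(=O)N/N=C(C)/C=N/Nc2ccc([N+](=O)[O-])cc2)cc1` stands at a limit of an ADME assay on J774 cells (Mus musculus, strain BALB/c) for cytotoxicity, read by resazurin assay, with a stated time of 72 h; a lower number here means that less compound is tolerated, a higher number that more compound is tolerated: the value > 100000 nM recorded for compound 2 is a limit, not a number. Compound 1 `CC(/C=N/Nc1ccc([N+](=O)[O-])cc1)=N\NC(=O)c1cccc(C)c1` also stands at a limit, giving > 100000 nM. The step that the two limits leave unreadable from compound 1 to compound 2 is therefore unreadable, as the limit of > 100000 nM in this assay, at which 2 of the 2 values shown sit, shows. Compound 3 `CC(/C=N/Nc1ccc([N+](=O)[O-])cc1)=N\NC(=O)c1ccc(Cl)cc1` differs from compound 2 by chloro in place of methoxy on an aromatic carbon. Among the measured compounds shown here, no measured step of readable size bears on this change, so no step beyond the scatter is expected in this assay. Compound 3 is expected to give about 150000 nM, between 50000 nM and 500000 nM. The expected step that the limit leaves unreadable from compound 2 to compound 3 lies within the scatter.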

Compound 3, half-maximal cytotoxic concentration: 63900 nM
Compound 3: the middle estimate sits 2.3-fold (0.37 log units) above what was measured; the measured number falls inside the stated range.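

In this assay, among the compounds shown here, compound 3 gives 63900 nM, the first number that is not a limit. Chloro in place of methoxy gives an at least 1.5-fold lower number from compound 2 to compound 3 (0.19 log units; that floor lies within the scatter), and 4-chlorophenyl in place of 3-methylphenyl gives an at least 1.5-fold lower number from compound 1 to compound 3 (0.19 log units; that floor lies within the scatter), so a 4-chlorophenyl group brings the value into readable range, but neither floor establishes a change beyond the scatter. The step between compound 1 and compound 2 remains unreadable: the limit of > 100000 nM in this assay, at which 2 of the 3 values shown sit.

From the compounds shown here alone, how far the true steps exceed these floors stays open. So does whether an amine or a carboxylic acid on this aromatic carbon would give a number or a limit.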